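Adding a second methoxy group to a stilbene-like core

The source may hold more compounds than are shown below. What is called first, only, known or untested is meant among the compounds shown, and "the series" means these compounds.

Measured so far, in a functional assay on MCF7 cells (Homo sapiens) for inhibition, read by sulforhodamine B assay, with a stated time of 48 h; on this read-out lower numbers stand for stronger inhibition of growth and higher numbers for weaker inhibition of growth:
- compound 1, `COc1ccc(/C=C/c2cc(=O)cco2)cc1`, gives 396 uM
- compound 2, `COc1ccc(/C=C/c2cc(=O)cco2)cc1OC`, gives 954 uM
- compound 3, `COc1ccc(/C=C/C2CC=CC(=O)N2)cc1`, gives only a limit of the assay, > 1090 uM

Compound 2 differs from compound 1 in one place, (methoxy in place of hydrogen on an aromatic carbon), and this change gave a 2.4-fold higher number from compound 1 to compound 2 (0.38 log units; beyond the scatter), so growth inhibition became weaker. Compound 3 carries a different core; the difference between the two cores is not broken down here. For compound 3 the assay reports no number, only the limit (the limit of > 1090 uM in this assay, at which 1 of the 3 values shown sits).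

Compound 4, `COc1ccc(/C=C/C2CC=CC(=O)N2)c(OC)c1`, is not yet measured. It differs from compound 3 by methoxy in place of hydrogen on an aromatic carbon. This is the same kind of change as from compound 1 to compound 2, though the surroundings differ: in compound 2 the new methoxy sits ortho to a methoxy group and meta to a group of 9 heavy atoms, whereas in compound 4 it sits ortho to a group of 9 heavy atoms and meta to a methoxy group. Because compound 1 to compound 2 gave a 2.4-fold higher number from compound 1 to compound 2 (0.38 log units; beyond the scatter), the step for compound 4 is expected to be a step that the limit leaves unreadable from compound 3 to compound 4, and since compound 3 already sits at a limit, compound 4 is expected to give 1800 uM in this assay, most likely again only as a limit, with a range of 1000 uM to 4000 uM.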

Compound 4, concentration for growth inhibition (reported as GI): > 964 uM
Compound 4 ended at the assay's limit (the forecaster's own chance of this, stated with the estimate: 85%); the middle value is on the limit's open side.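

Compound 3 gives only a limit, not a number: the limit of > 1090 uM in this assay, at which 1 of the 4 values shown sits. Compound 4 also gives only a limit, so the step from compound 3 to compound 4 cannot be read: the limit of > 964 uM in this assay, at which 1 of the 4 values shown sits.

The compounds shown leave open whether the added methoxy weakens growth inhibition on the core of compound 3, as it did from compound 1 to compound 2.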